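This account rests on a few compounds, and the source may have more. Where it says the series, first, only, none or still open, it means among the compounds named here.

Compound 1 `CCCCCCCC/C=C\CCCCCCC(=O)c1nc2cnccc2o1` gives 7.2 nM in an assay on isolated protein for inhibition of Fatty-acid amide hydrolase 1 (Homo sapiens); on this read-out lower numbers stand for stronger inhibition and higher numbers for weaker inhibition. Compound 2 `CCCCCCCC/C=C\CCCCCCC(=O)c1ccccn1` reaches only a limit of the assay, > 100000 nM, in this assay. The step of an at least 13000-fold higher number from compound 1 to compound 2 (4.14 log units; beyond the scatter) is therefore known only as a lower bound, since it rests on (the limit of > 100000 nM in this assay, at which 1 of the 2 values shown sits). Compound 3 `CCCCCCCC/C=C\CCCCCCC(=O)c1nnn(C)n1` differs from compound 2 by 2-methyl-2H-tetrazol-5-yl in place of pyridin-2-yl on a carbonyl carbon. For the measured compounds named here, no measured step covers this exact change; the one measured step, an at least 13000-fold higher number from compound 1 to compound 2 (4.14 log units; beyond the scatter), shows only that the group on the carbonyl carbon governs the whole read-out and that the pyridin-2-yl of compound 2 leaves nothing measurable. A different group on that carbon may therefore bring back measurable inhibition, toward lower numbers in this assay, but its size cannot be read from a limit. Compound 3 is estimated at 300 nM in this assay, within 30 nM to 5000 nM. That estimate means an expected step of an at least 330-fold lower number from compound 2 to compound 3 (2.52 log units; beyond the scatter).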

Compound 3, inhibition constant: 65 nM
For compound 3 the middle estimate is 4.6-fold (0.66 log units) above the measured one; measured number inside the range.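

With the chain and the carbonyl unchanged, the group on the carbonyl carbon can alone take the read-out in this assay from no measurable inhibition to a clear value, as 2-methyl-2H-tetrazol-5-yl in place of pyridin-2-yl gives an at least 1500-fold lower number from compound 2 to compound 3 (3.18 log units; beyond the scatter) on the same carbon. That step is only a lower bound, since compound 2 stands at a limit of the assay: (the limit of > 100000 nM in this assay, at which 1 of the 3 values shown sits). For the compounds shown here, the six-membered ring in the group of compound 1 is not required for measurable inhibition, though the single ring of compound 3 does not match that group, with a 9.0-fold higher number from compound 1 to compound 3 (0.96 log units; beyond the scatter) beyond the scatter.

Going by these compounds, it remains open whether the tetrazole's methyl matters, and how an ethyl or a hydrogen in its place would read. Also open, on these data alone, is how a plain oxazole or a 1,3,4-oxadiazole on the carbonyl carbon would compare.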